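The compounds below may be only part of what the source reports. "The series", "measured", "known", "first", "only" and "open" are said of these compounds alone.

Measured so far in an assay on cells (Oocyte) for negative allosteric modulation of glutamate receptor ionotropic, NMDA 2D (Rattus norvegicus), read by two-electrode voltage clamp; on this read-out higher numbers stand for weaker inhibition and lower numbers for stronger inhibition:
compound 1 `O=C(O)CCC(=O)N1N=C(c2c(-c3ccc(Br)cc3)c3ccccc3[nH]c2=O)CC1c1ccc(Cl)cc1`: 290 nM
compound 2 `O=C(O)CCC(=O)N1N=C(c2c(-c3ccc(C(F)(F)F)cc3)c3ccccc3[nH]c2=O)CC1c1ccc(Cl)cc1`: 2800 nM

Compound 2 stands highest of the two numbers in this assay; the nearest is compound 1, reached by a 9.7-fold higher number from compound 1 to compound 2 (0.98 log units; beyond the scatter). Compound 3 `O=C(O)CCC(=O)N1N=C(c2c(-c3cccc(C(F)(F)F)c3)c3ccccc3[nH]c2=O)CC1c1ccc(Cl)cc1` differs from compound 2 by 3-(trifluoromethyl)phenyl in place of 4-(trifluoromethyl)phenyl on an aromatic carbon. No measured step bears on moving the trifluoromethyl to another ring position; the single step shown, a 9.7-fold higher number from compound 1 to compound 2 (0.98 log units; beyond the scatter), exchanges one group for another at the same place and gives no size for this change. The step of a 1.1-fold lower number from compound 2 to compound 3 (0.05 log units; within the scatter) is therefore expected to stay within the scatter. For compound 3 the estimate in this assay is 2500 nM, range 800 nM to 8000 nM.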

Compound 3, half-maximal inhibitory concentration: 2600 nM
Estimate against measurement, compound 3: 1.0-fold (0.02 log units) below; low and high end bracket the measured number.
By their numbers in this assay, from the lowest: compound 1; then compounds 3 and 2 (each within the scatter of the next).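

In this assay, 3-(trifluoromethyl)phenyl in place of 4-(trifluoromethyl)phenyl gives a 1.1-fold lower number from compound 2 to compound 3 (0.03 log units; within the scatter), so these two ring placements of trifluoromethyl are not told apart here. The step of a 9.0-fold higher number from compound 1 to compound 3 (0.95 log units; beyond the scatter) shows that compound 1 stays apart from the 3-(trifluoromethyl)phenyl compound as well as from the 4-(trifluoromethyl)phenyl compound. No evidence at hand accounts for this result.

Open, going by these compounds, is whether bromo depends on its ring place as little as trifluoromethyl does. Also open, on these data alone, is whether chloro, methyl or an amine on this phenyl would give numbers like those of compound 1 or those of compound 2 and compound 3.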